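This account rests on a few compounds, and the source may have more. Where it says the series, first, only, none or still open, it means among the compounds named here.

Working notes on the series. Three analogues sharing one core have been measured in a functional assay on NCI-H460 cells (Homo sapiens) for antiproliferative activity, read by MTT assay, with a stated time of 72 h; a lower number here means a stronger inhibitor, a higher number a weaker inhibitor. Compound 1 `CCCNC(=O)c1cc(Oc2ccc(NC(=O)c3cc4cccnc4n(-c4ccccc4F)c3=O)cc2)ccn1` gives 390 nM. Compound 2 `CCCNC(=O)c1cc(Oc2ccc(NC(=O)c3cc4cccnc4n(-c4ccc(F)cc4)c3=O)cc2)ccn1` gives 120 nM. Compound 3 `CCCNC(=O)c1cc(Oc2ccc(NC(=O)c3cc4cccnc4n(-c4ccc(OC)cc4)c3=O)cc2)ccn1` gives 1730 nM, the highest number of the three, with the nearest being compound 1 and the furthest compound 2; both of those gaps lie beyond the scatter.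

The next compound, compound 4 `CCCNC(=O)c1cc(Oc2ccc(NC(=O)c3cc4cccnc4n(-c4ccc(C(F)(F)F)cc4Cl)c3=O)cc2)ccn1`, is compound 3 with a change: 2-chloro-4-(trifluoromethyl)phenyl in place of 4-methoxyphenyl on an aromatic nitrogen. Among the compounds with values here, two measured steps bear on it. The step of a 14-fold higher number from compound 2 to compound 3 (1.16 log units; beyond the scatter) shows that exchanging methoxy for fluoro on the aromatic carbon moves the number a long way, so removing methoxy in favour of fluorine-bearing and chlorine-bearing substituents is expected to bring the number down. The step of a 3.3-fold lower number from compound 1 to compound 2 (0.51 log units; beyond the scatter) shows that a group ortho to the core attachment costs something, and compound 4 carries chloro there. The net step from compound 3 to compound 4 is therefore expected to be a 4.9-fold lower number from compound 3 to compound 4 (0.69 log units; beyond the scatter), lower but not reaching compound 2. For compound 4 the expected value in this assay is 350 nM, with a range from 80 nM to 1500 nM.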

Compound 4, half-maximal inhibitory concentration: 3170 nM
Beside the measured number, compound 4's estimate is 9.1-fold (0.96 log units) below it; the measured number lies above the stated range.
By their numbers in this assay, from the lowest: compound 2; then compound 1; then compounds 3 and 4 (each within the scatter of the next).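

this assay gives a 1.8-fold higher number from compound 3 to compound 4 (0.26 log units; within the scatter), so 2-chloro-4-(trifluoromethyl)phenyl and 4-methoxyphenyl on the aromatic nitrogen cannot be told apart here, and replacing the methoxy-bearing group with a halogen-bearing one does not by itself bring the number down. The same group gives a 26-fold higher number from compound 2 to compound 4 (1.42 log units; beyond the scatter) and an 8.1-fold higher number from compound 1 to compound 4 (0.91 log units; beyond the scatter), so among these four compounds a low number goes with the two phenyl groups that carry a single fluoro, not with halogen substitution as such. No data at hand account for this result.

The contributions of chloro and trifluoromethyl remain unseparated, as the two occur only together in compound 4. From the compounds shown here alone, how an amine or a carboxylic acid in place of the trifluoromethyl would read remains open.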